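The compounds below may be only part of what the source reports. "The series", "measured", "known", "first", "only" and "open" are said of these compounds alone.

Measured compounds:
compound 1, `Cc1c(C(=O)Nc2ccc(Oc3ccnc4[nH]ccc34)c(F)c2)nnn1-c1ccc(F)cc1` — 4350 nM
compound 2, `Cc1c(C(=O)Nc2ccc(Oc3ccnc4[nH]ccc34)c(F)c2)nnn1-c1ccc(F)c(Cl)c1` — "not determined" (no result reported)

In a functional assay on PC-3 cells (Homo sapiens) for cytotoxicity, read by MTT assay, with a stated time of 72 h (a higher number here means a weaker inhibitor, a lower number a stronger inhibitor), compound 1 gives 4350 nM. Among the measured compounds shown here, compound 1 stands as the only member of the series with a number; compound 2 has no result, so no step between two measured compounds can be drawn and nothing about the size or direction of a change is known from measurement.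

Compound 3 is `Cc1c(C(=O)Nc2ccc(Oc3ccnc4[nH]ccc34)cc2)nnn1-c1ccc(F)cc1`. Compound 3 differs from compound 1 by hydrogen in place of fluoro on an aromatic carbon. The shared core, the amide and the ether link are untouched; only the fluoro on the aromatic carbon of the six-membered ring leaves, and a hydrogen enters in its place.

For the measured compounds named here, with no measured step to lean on, a small move is expected, of a size at or just beyond the scatter, and if anything toward a weaker value. The step of a 1.4-fold higher number from compound 1 to compound 3 (0.14 log units; within the scatter) is expected to be modest. For compound 3 the estimate in this assay is 6000 nM, with a range from 2500 nM to 15000 nM, and a fair chance that a single number is again reported rather than a limit.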

Compound 3, half-maximal inhibitory concentration: 3450 nM
Compound 3: the middle estimate sits 1.7-fold (0.24 log units) above what was measured, and the stated range covers the measured number.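

In this assay, among the compounds shown here, the one readable step is a 1.3-fold lower number from compound 1 to compound 3 (0.10 log units; within the scatter), so taking the fluoro off this aromatic carbon, ortho to a large group and meta to a large group, and leaving hydrogen there gives a read-out that cannot be told apart from that of compound 1. On this single pair, the fluoro at this position is not needed to hold the cytotoxicity level of compound 1, and compound 3, with one heavy atom fewer and the amide and ether link unchanged, can stand beside compound 1 as an equal reference point for further comparison. No independent measurement is available to explain why the two compounds read alike.

As far as these compounds go, only fluoro and hydrogen have been read at this carbon, so it remains open whether a methoxy, an amine or a carboxylic acid there would give a step beyond the scatter. From the compounds shown here alone, it is also open whether hydrogen in place of the fluoro on the other six-membered ring would read as quietly as this change.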